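This account rests on a few compounds, and the source may have more. Where it says the series, first, only, none or still open, it means among the compounds named here.

Measured in a functional assay on ECa-109 cells (Homo sapiens) for antiproliferative activity, read by MTT assay, with a stated time of 48 h; on this read-out lower numbers stand for stronger inhibition and higher numbers for weaker inhibition:
- Compound 1 `Cn1cc(C2=C(c3nn(CCCn4cncn4)c4ncccc34)C(=O)N(c3ccccc3)C2=O)c2ccccc21`: > 100000 nM (a limit of the assay)
- Compound 2 `Cn1cc(C2=C(c3nn(CCCn4ccnc4)c4ncccc34)C(=O)N(c3ccccc3)C2=O)c2ccccc21`: 1440 nM

Among the compounds with values here, compound 2 holds the only actual number in this small set. Compound 1 stands at the limit of > 100000 nM in this assay, at which 1 of the 2 values shown sits.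

Compound 3 `CN(C)CCCn1nc(C2=C(c3cn(C)c4ccccc34)C(=O)N(c3ccccc3)C2=O)c2cccnc21` departs from compound 2 by a single change: dimethylamino in place of 1H-imidazol-1-yl on a saturated chain carbon, three bonds along the chain from an aromatic nitrogen. It carries dimethylamino in place of 1H-imidazol-1-yl on a saturated chain carbon, three bonds along the chain from an aromatic nitrogen, so that 3-(1H-imidazol-1-yl)propyl becomes 3-(dimethylamino)propyl.

Within the data shown here, one measured step bears on this place: an at least 69-fold lower number from compound 1 to compound 2 (1.84 log units; beyond the scatter). It is large and shows that exchanging the end group here can move the read-out strongly. However, it links two ring groups and gives no direction for a group without a ring. A moderate move in this assay is therefore expected, leaning towards weaker inhibition, with wide margins. The expected change is a 1.7-fold higher number from compound 2 to compound 3 (0.24 log units; within the scatter). For compound 3 the estimated value is 2500 nM, with an expected range of 400 nM to 20000 nM.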

Compound 3, half-maximal inhibitory concentration: 5840 nM
Estimate against measurement, compound 3: 2.3-fold (0.37 log units) below, within the range that was stated.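

In this assay, replacing 1H-imidazol-1-yl with dimethylamino weakens inhibition only modestly, with a 4.1-fold higher number from compound 2 to compound 3 (0.61 log units; beyond the scatter), so a ring in the end group at this place is not required for a measurable value. The ring-free group also reads far stronger than the 1H-1,2,4-triazol-1-yl end group, with an at least 17-fold lower number from compound 1 to compound 3 (1.23 log units; beyond the scatter), so among the three end groups shown, the order runs from 1H-imidazol-1-yl through dimethylamino to 1H-1,2,4-triazol-1-yl, and the triazole is the one that stands apart. The triazole end of that order rests on a limit of the assay and not on a number: the limit of > 100000 nM in this assay, at which 1 of the 3 values shown sits.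

The compounds shown leave open how a cyclic amine such as morpholine or piperidine, or a 1H-pyrazol-1-yl ring, would read at the end of this chain, and so whether the sharp drop belongs to the triazole alone. They also leave open whether the same order of end groups holds on a shorter 2-(dimethylamino)ethyl chain or on a longer chain than propyl.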